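The compounds below may be only part of what the source reports. "The series", "measured", "known", "first", "only" and "open" are said of these compounds alone.

Measured compounds in an ADME assay on A549 cells (Homo sapiens) for cytotoxicity, read by MTT assay, with a stated time of 48 h; on this read-out lower numbers stand for stronger inhibition of growth and higher numbers for weaker inhibition of growth:

compound 1 `O=C(/C=C\c1ccccc1[N+](=O)[O-])N1N=C(c2ccncc2)OC1c1c[nH]c2ccccc12` — compound 1 gives > 30 ug/mL, a limit of the assay and not a number.
compound 2 `O=C(/C=C\c1cccc([N+](=O)[O-])c1)N1N=C(c2ccncc2)OC1c1c[nH]c2ccccc12` — compound 2 gives > 30 ug/mL, likewise a limit.
compound 3 `O=C(/C=C\c1ccc([N+](=O)[O-])cc1)N1N=C(c2ccncc2)OC1c1c[nH]c2ccccc12` — compound 3 gives > 30 ug/mL, likewise a limit.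

Compound 2 stands at the limit of > 30 ug/mL in this assay, at which 3 of the 3 values shown sit, so its place among the three is not resolved. The steps a step that the two limits leave unreadable from compound 1 to compound 2, a step that the two limits leave unreadable from compound 1 to compound 3 and a step that the two limits leave unreadable from compound 2 to compound 3 all remain unreadable for the same reason. Compound 4 `O=C(/C=C\c1ccc(Cl)cc1Cl)N1N=C(c2ccncc2)OC1c1c[nH]c2ccccc12` is the next member. The change 2,4-dichlorophenyl in place of 3-nitrophenyl on a double-bonded chain carbon bound to a double-bonded chain carbon is of a different kind from the moves of the nitro group among the measured compounds, so none of those steps directly covers it. With every value sitting at the limit, no direction or size can be expected in this assay beyond that limit, and compound 4 is estimated to follow the others with a step that the limit leaves unreadable from compound 2 to compound 4. Compound 4 is therefore expected at 40 ug/mL, between 15 ug/mL and 150 ug/mL.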

Compound 4, concentration for 50% growth inhibition: > 30 ug/mL
Compound 4: only a limit was reported (the forecaster's own chance of this, stated with the estimate: 70%); the middle value does not contradict the limit.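

In this assay compound 4 gives > 30 ug/mL, a limit and not a number. The steps from compound 1, compound 2 and compound 3 to compound 4 therefore cannot be read: the limit of > 30 ug/mL in this assay, at which 4 of the 4 values shown sit. On these data alone, whether the nitrophenyl isomers and 2,4-dichlorophenyl differ at all in this assay stays open.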